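The source may hold more compounds than are shown below. What is called first, only, known or untested is meant among the compounds shown, and "the series" means these compounds.

Measured compounds and values:

- compound 1 `COC(=O)CCn1sc(Cl)c(Cl)c1=O` — an assay on isolated protein for inhibition of histone acetyltransferase KAT2B (Homo sapiens), read by fluorescence, with a stated time of 15 min; a higher number here means a weaker inhibitor, a lower number a stronger inhibitor: 2600 nM
- compound 2 `CCCCCCCCCCCCSc1cc(=O)n(C(C)(C)C)[s+]1[O-]` — this assay: > 10000 nM
- compound 3 `CCCCCCCCCCCCSc1cc(=O)n(CCC(=O)OC)[s+]1[O-]` — this assay: > 10000 nM

Compound 3 `CCCCCCCCCCCCSc1cc(=O)n(CCC(=O)OC)[s+]1[O-]` stands only at a limit of this assay, > 10000 nM, not at a number. Compound 2 likewise reaches only a limit, > 10000 nM. Among the measured compounds shown here, the single step, a step that the two limits leave unreadable from compound 2 to compound 3, is therefore unreadable; both ends sit at the limit of > 10000 nM in this assay, at which 2 of the 3 values shown sit. For the measured compounds named here, compound 1 is the one member with a numeric value, 2600 nM, and no step connects it to compound 3, so its value can only be set beside the others without a comparison.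

Compound 4 `CCCCCCCCCCCCSc1c(Cl)c(=O)n(CCC(=O)OC)[s+]1[O-]` differs from compound 3 by chloro in place of hydrogen on an aromatic carbon. No measured step in the series bears on this change: the only step shown, from compound 2 to compound 3, is itself unreadable, and nothing else varies the same position. The expectation for compound 4 in this assay is therefore weak; it is expected to lie near the limit where compound 3 sits, with a wide range, and the step of an at least 1.1-fold lower number from compound 3 to compound 4 (0.04 log units; that floor lies within the scatter) is estimated as small, without a readable direction. Compound 4 is estimated at 9000 nM, between 2500 nM and 30000 nM.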

Compound 4, half-maximal inhibitory concentration: > 10000 nM
Compound 4 was reported as a limit; the forecaster's own chance of this, stated with the estimate: 60%; middle value at least 1.1-fold (0.04 log units) from the limit.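

In this assay compound 4 stands at > 10000 nM, a limit and not a number. Compound 3 stands at > 10000 nM, also a limit, so no step can be read between compound 3 and compound 4, and the series stays at the assay's edge: the limit of > 10000 nM in this assay, at which 3 of the 4 values shown sit.

The compounds shown leave open whether chloro in place of hydrogen on an aromatic carbon changes the inhibition at all.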